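The source may report more compounds than this note shows. Statements on the series, on what has been measured and on what is new or still open speak of the compounds shown alone.

The measured compounds:
Compound 1, `COc1cc(-c2nnc3n2NC(c2ccco2)C(C(=O)c2ccccc2C)S3)cc(OC)c1OC`, gives 69900 nM.
Compound 2, `COc1cc(-c2nnc3n2NC(c2ccco2)C(C(=O)C2CC2)S3)cc(OC)c1OC`, gives > 100000 nM, which is a limit of the assay and not a number.
Compound 3, `COc1cc(-c2nnc3n2NC(c2ccco2)C(C(=O)c2ccc([N+](=O)[O-])cc2)S3)cc(OC)c1OC`, gives > 100000 nM, which is also a limit of the assay.

These values come from a functional assay on MCF7 cells (Homo sapiens) for cytotoxicity, read by MTT assay, with a stated time of 48 h; a lower number here means a stronger inhibitor, a higher number a weaker inhibitor. Among the measured compounds shown here, compound 1 holds the only number in this set. The remaining two values sit at the limit of > 100000 nM in this assay, at which 2 of the 3 values shown sit.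

Compound 4, `COc1cc(-c2nnc3n2NC(c2ccco2)C(C(=O)c2ccc(-c4ccccc4)cc2)S3)cc(OC)c1OC`, has not yet been measured in this assay. It differs from compound 1 by 4-phenylphenyl in place of 2-methylphenyl on a carbonyl carbon. Two measured steps change the same group on the carbonyl carbon and so bear on this one: an at least 1.4-fold higher number from compound 1 to compound 2 (0.15 log units; that floor lies within the scatter) and an at least 1.4-fold higher number from compound 1 to compound 3 (0.15 log units; that floor lies within the scatter). Both replacements of 2-methylphenyl moved the number beyond what this assay reports, though in each case the floor of the step lies within the scatter. The step between the two limits cannot be read: a step that the two limits leave unreadable from compound 2 to compound 3. The change to 4-phenylphenyl is a third replacement at the same place, and since both steps seen run toward a higher number, compound 4 is expected to show a step of a 1.7-fold higher number from compound 1 to compound 4 (0.23 log units; within the scatter), toward a weaker inhibitor, quite possibly ending at the limit. Compound 4 is therefore estimated at 120000 nM, with a range from 40000 nM to 300000 nM.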

Compound 4, half-maximal inhibitory concentration: > 100000 nM
Compound 4: no number, only a limit; the forecaster's own chance of this, stated with the estimate: 60%; the middle value lies beyond the limit too.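

The change to 4-phenylphenyl gives an at least 1.4-fold higher number from compound 1 to compound 4 (0.15 log units; that floor lies within the scatter) in this assay, and this floor is all that can be said of its size. Compound 4 extends the earlier picture to a group with two six-membered aromatic rings of carbon only: like cyclopropyl and 4-nitrophenyl, it gives no number at this carbonyl carbon, and its steps from compound 2 and compound 3 cannot be read, since both ends of each are limits. Among the four groups shown at this place, only the 2-methylphenyl of compound 1 gives a number, 69900 nM. The set now sits largely at a limit of the assay: the limit of > 100000 nM in this assay, at which 3 of the 4 values shown sit.

The compounds shown leave open whether that number depends on the methyl group of compound 1, which a plain phenyl or a 2-chlorophenyl on the same carbonyl carbon would test. They also leave open whether any group at this place, such as a 2-methoxyphenyl or a 2-aminophenyl, would give a number clearly lower than that of compound 1.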